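Selenium for sulfur on the shared core: series notes

The source may report more compounds than this note shows. Statements on the series, on what has been measured and on what is new or still open speak of the compounds shown alone.

Measured in a functional assay on MCF7 cells (Homo sapiens) for cytotoxicity, read by MTT assay, with a stated time of 72 h; on this read-out lower numbers stand for stronger inhibition of growth and higher numbers for weaker inhibition of growth:
- compound 1 `COc1ccc(CNc2nc([Se]C)nc3ccccc23)cc1`: 98600 nM
- compound 2 `COc1ccc(CNc2nc(SC)nc3ccccc23)cc1`: 85100 nM
- compound 3 `CSc1ccc(CNc2nc(SC)nc3ccccc23)cc1`: > 100000 nM, a limit of this assay, not a number

Compound 2 and compound 1 differ by a group of 2 heavy atoms (1 carbon, 1 selenium; no ring) in place of a group of 2 heavy atoms (1 carbon, 1 sulfur; no ring), on an aromatic carbon; the step is a 1.2-fold higher number from compound 2 to compound 1 (0.06 log units; within the scatter). The cores of compound 2 and compound 3 differ by methylsulfanyl in place of methoxy on an aromatic carbon; that step is an at least 1.1-fold higher number from compound 2 to compound 3 (0.07 log units; that floor lies within the scatter), and compound 3 sits at the limit of > 100000 nM in this assay, at which 1 of the 3 values shown sits. Compound 4 `CSc1ccc(CNc2nc([Se]C)nc3ccccc23)cc1` is not yet measured in this assay. It differs from compound 3 by a group of 2 heavy atoms (1 carbon, 1 selenium; no ring) in place of a group of 2 heavy atoms (1 carbon, 1 sulfur; no ring), on an aromatic carbon, the same change as made between compound 2 and compound 1. For compound 4 the expected step is a step that the limit leaves unreadable from compound 3 to compound 4, resting on the within-scatter step a 1.2-fold higher number from compound 2 to compound 1 (0.06 log units; within the scatter) and on compound 3 standing at the limit of > 100000 nM in this assay, at which 1 of the 3 values shown sits. Compound 4 is therefore estimated at 120000 nM, between 70000 nM and 250000 nM, and most likely reported only as a limit.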

Compound 4, concentration for total growth inhibition: > 100000 nM
Compound 4 was reported as a limit; the forecaster's own chance of this, stated with the estimate: 75%; the middle value does not contradict the limit.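

In this assay compound 4 gives > 100000 nM, a limit of the assay and not a number. The selenium-for-sulfur step on this second core cannot be read, so the earlier within-scatter result, a 1.2-fold higher number from compound 2 to compound 1 (0.06 log units; within the scatter), is neither confirmed nor contradicted, and nothing shows that this change carries from one core to the other. With the selenium-bearing group in place, methylsulfanyl in place of methoxy gives an at least 1.0-fold higher number from compound 1 to compound 4 (0.00 log units; that floor lies within the scatter), and set beside the same change on the sulfur-bearing core: the same change on two cores in this assay, an at least 1.1-fold higher number (0.07 log units; that floor lies within the scatter) from compound 2 to compound 3 and an at least 1.0-fold higher number (0.00 log units; that floor lies within the scatter) from compound 1 to compound 4; the limit leaves it open whether they differ.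

Still open, going by these compounds, is whether an amine or a carboxylic acid in place of methoxy would give a readable value in this assay. The same holds for a longer chain in place of the selenium-bearing or sulfur-bearing group.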